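The source may hold more compounds than are shown below. What is called first, only, known or untested is meant among the compounds shown, and "the series" means these compounds.

Compound 1 `CCC(=O)N1CC[C@H](Oc2ncnc3c2CN(c2ccc(OC)nc2)CC3)C1` gives 35 uL/min in an ADME assay on microsomes from liver (Rattus norvegicus) for metabolic stability; a lower number here means slower removal, a higher number faster removal of the compound.
Compound 2 `COc1ccc(N2CCc3ncnc(-c4cccc(OC5CCN(C(C)=O)CC5)c4)c3C2)cn1` gives 197 uL/min in this assay.
Compound 3 `COc1ccc(N2CCc3ncnc(-c4cccc(C(=O)N5CCN(C(C)=O)CC5)c4)c3C2)cn1` gives 91 uL/min in this assay.

Of the three, compound 1 gives the lowest number; compound 3 is nearest to it and compound 2 furthest, both gaps beyond the scatter. Going by the values given here, the only single-site step measured so far is a 2.2-fold lower number from compound 2 to compound 3 (0.34 log units; beyond the scatter), which concerns a different position of the shared core and does not involve the change now considered. Compound 4 `CCC(=O)N1CC[C@H](Oc2ncnc3c2CN(c2cnc(OC)c(C(F)(F)F)c2)CC3)C1` differs from compound 1 by trifluoromethyl in place of hydrogen on an aromatic carbon. Among the compounds with values here, no measured pair covers this change, so the expectation for compound 4 rests on compound 1 alone: it is expected to show a 1.2-fold lower number from compound 1 to compound 4 (0.07 log units; within the scatter), a step not clearly beyond the scatter in either direction. Compound 4 is therefore estimated at 30 uL/min, with a range from 12 uL/min to 80 uL/min.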

Compound 4, intrinsic clearance in a liver preparation (reported as CLH), per the amount of preparation that the assay uses: 160 uL/min
The estimate for compound 4 lay 5.3-fold (0.73 log units) below the measured number, and the stated range ends below it.
By their numbers in this assay, from the lowest: compound 1; then compounds 3, 4 and 2 (each within the scatter of the next, the first and the last beyond it).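

Placing trifluoromethyl in place of hydrogen on this aromatic carbon, ortho to a methoxy group, gives a 4.6-fold higher number from compound 1 to compound 4 (0.66 log units; beyond the scatter) in this assay. Going by these compounds alone, this is the first measured change on this ring, and it shows that the position is not indifferent in this assay: the step lies beyond the scatter, towards faster removal. No measurement at hand explains this step. As far as these compounds go, what remains open is how a methyl group, a chlorine atom or a nitrile would behave at the same carbon. From the compounds shown here alone, whether trifluoromethyl would give a similar step on compound 2 or compound 3 also remains open.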